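The source may hold more compounds than are shown below. What is called first, only, known or untested is meant among the compounds shown, and "the series" means these compounds.

Measured so far in a functional assay on KYSE-450 cells (Homo sapiens) for inhibition, read by MTT assay, with a stated time of 48 h; a lower number here means a stronger inhibitor, a higher number a weaker inhibitor:
Compound 1 `COCC(=O)N(Cc1ccc(OC)c(O)c1)c1cc(OC)c(OC)c(OC)c1` gives 460 nM
Compound 2 `CC/C=C/C(=O)N(Cc1ccc(OC)c(O)c1)c1cc(OC)c(OC)c(OC)c1` gives 72 nM
Compound 3 `COc1ccc(CN(C(=O)CCCCCl)c2cc(OC)c(OC)c(OC)c2)cc1O` gives 770 nM

Compound 3 stands at the high-number end of this small set, the side of weaker inhibition. One measured step (a 1.7-fold higher number from compound 1 to compound 3 (0.22 log units; within the scatter)) stays inside the usual scatter, while another (an 11-fold higher number from compound 2 to compound 3 (1.03 log units; beyond the scatter)) goes well beyond it.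

Compound 4 `COc1ccc(CN(C(=O)C2CC2)c2cc(OC)c(OC)c(OC)c2)cc1O` keeps the shared core and carries cyclopropyl in place of 4-chlorobutyl on a carbonyl carbon. The three measured compounds differ only in the group at this same place, so their steps are the best guide available. Besides the two above, there is a modest one (a 6.4-fold lower number from compound 1 to compound 2 (0.81 log units; beyond the scatter)). Together they show that a change here can clearly move the number in this assay. Among the compounds with values here, none of the three carries a ring at this place, however, so cyclopropyl has no direct precedent.

Within the data shown here, with compound 3 at 770 nM near the top of the set, a new group here seems more likely to lower the number than to raise it, although that rests on only three compounds. A modest drop is expected (a 3.9-fold lower number from compound 3 to compound 4 (0.59 log units; beyond the scatter)). For compound 4 the estimated value is 200 nM with an expected range from 50 nM to 800 nM in this measurement.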

Compound 4, half-maximal inhibitory concentration: 80 nM
The estimate for compound 4 lay 2.5-fold (0.40 log units) above the measured number, within the range that was stated.
By their numbers in this assay, from the lowest: compounds 2 and 4 (each within the scatter of the next); then compounds 1 and 3 (each within the scatter of the next).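

In this assay cyclopropyl, the first ring at this place on the carbonyl carbon, gives a 9.6-fold lower number from compound 3 to compound 4 (0.98 log units; beyond the scatter) in place of 4-chlorobutyl and a 5.8-fold lower number from compound 1 to compound 4 (0.76 log units; beyond the scatter) in place of methoxymethyl. Set against but-1-en-1-yl, it gives a 1.1-fold higher number from compound 2 to compound 4 (0.05 log units; within the scatter) so compound 2 and compound 4 cannot be told apart, which shows that a ring and an open chain can both reach this low level. Across the four compounds a new split appears: the two groups made only of carbon and hydrogen give the lower pair of numbers, the two carrying an oxygen or a chlorine atom give the higher pair, and no compound shown goes against this, though four compounds are a thin base.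

A plain butyl chain would show whether 4-chlorobutyl sits high on account of its chlorine or its saturated chain, and cyclobutyl or a chain ending in an amine would test how far the split holds. Nothing available explains why these groups move the number in this way.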